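Thiazolyl in Place of Dimethylphenyl: Expected Clearance

The source may hold more compounds than are shown below. What is called first, only, known or untested is meant among the compounds shown, and "the series" means these compounds.

Within the data shown here, compound 3 `Cc1ccc([C@H](C)NC(=O)Cn2nnc3ccccc3c2=O)c(C)c1` is the only member of this small set that gives a number rather than a limit in an ADME assay on microsomes from liver (Homo sapiens) for metabolic stability; a higher number here means faster removal of the compound, a lower number slower removal: compound 3 gives 33 mL/min/kg. Compound 1 `C[C@H](NC(=O)Cn1nnc2ccccc2c1=O)c1ccc(Cl)cc1` sits at a limit of the assay, since compound 1 gives < 9.9 mL/min/kg in this assay. Compound 2 `C[C@H](NC(=O)Cn1nnc2ccccc2c1=O)c1ccc(Br)cc1` likewise sits at a limit, as compound 2 gives < 9.9 mL/min/kg. Two of the three values therefore share (the limit of < 9.9 mL/min/kg in this assay, at which 2 of the 3 values shown sit). The connecting steps are readable in one direction only: an at least 3.3-fold higher number from compound 1 to compound 3 (0.52 log units; beyond the scatter) and an at least 3.3-fold higher number from compound 2 to compound 3 (0.52 log units; beyond the scatter), whereas a step that the two limits leave unreadable from compound 1 to compound 2.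

Compound 4 `C[C@H](NC(=O)Cn1nnc2ccccc2c1=O)c1nccs1` has not yet been measured in this assay. It differs from compound 3 as follows: 1,3-thiazol-2-yl in place of 2,4-dimethylphenyl on a saturated chain carbon bound to an amide-type nitrogen and a saturated chain carbon. Both measured steps that bear on this change have the 2,4-dimethylphenyl entering at the same place and raising the number beyond the scatter; in the present step that group leaves. The expectation is therefore the reverse direction, a lower number for compound 4 than for compound 3, of a size comparable to those steps, so that the value may fall back toward the limit at which compounds 1 and 2 sit. The estimate for compound 4 is 12 mL/min/kg, with a range from 5 mL/min/kg to 30 mL/min/kg, which is expected to mean a step of a 2.8-fold lower number from compound 3 to compound 4 (0.44 log units; beyond the scatter).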

Compound 4, clearance: < 9.9 mL/min/kg
Compound 4: a limit, no number; the forecaster's own chance of this, stated with the estimate: 40%; at least 1.2-fold (0.08 log units) between middle value and limit.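

In this assay, the change from 2,4-dimethylphenyl to 1,3-thiazol-2-yl on a saturated chain carbon bound to an amide-type nitrogen and a saturated chain carbon gives an at least 3.3-fold lower number from compound 3 to compound 4 (0.52 log units; beyond the scatter), so the drop from compound 3 no longer rests on halogen-bearing phenyl groups alone. Among these compounds, the low end at this place is thus reached by a five-membered aromatic ring with 2 hetero atoms as well as by the six-membered rings of compound 1 and compound 2, and compound 3 is the one compound that goes against this grouping: the limit of < 9.9 mL/min/kg in this assay, at which 3 of the 4 values shown sit. The steps among compound 1, compound 2 and compound 4 cannot be read, as each of the three values is a limit and not a number, so no order among these compounds can be given.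

Going by these compounds, how far each of these three compounds lies under the limit remains open. Also open, on these data alone, is whether an unsubstituted phenyl, a pyridyl or a single methyl group on the phenyl ring at this place would stay at the limit or rise toward compound 3.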